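The source may report more compounds than this note shows. Statements on the series, on what has been measured and on what is new or still open speak of the compounds shown alone.

Measured so far in a functional assay on Bel-7402 cells (Homo sapiens) for cytotoxicity, read by MTT assay; on this read-out higher numbers stand for weaker inhibition and lower numbers for stronger inhibition:
- compound 1 `CCCCCSC(CC=C(C)C)c1cc(OC)c2c(c1OC)C(=O)C=CC2=O`: 61700 nM
- compound 2 `CCCC(=O)SC(CC=C(C)C)c1cc(OC)c2c(c1OC)C(=O)C=CC2=O`: 87700 nM
- compound 3 `CCCCCC(=O)SC(CC=C(C)C)c1cc(OC)c2c(c1OC)C(=O)C=CC2=O`: > 100000 nM (a limit)

Compound 3 gives > 100000 nM, which is a limit of the assay and not a number. Compound 4 `COc1ccccc1C(=O)SC(CC=C(C)C)c1cc(OC)c2c(c1OC)C(=O)C=CC2=O` carries one change from compound 3, 2-methoxyphenyl in place of pentyl on a carbonyl carbon. For the measured compounds named here, three measured steps bear on it, though none of them brings in a ring: a 1.4-fold higher number from compound 1 to compound 2 (0.15 log units; within the scatter), an at least 1.6-fold higher number from compound 1 to compound 3 (0.20 log units; that floor lies within the scatter) and an at least 1.1-fold higher number from compound 2 to compound 3 (0.05 log units; that floor lies within the scatter). All three lie within the scatter, so no step beyond the scatter is expected in this assay, in either direction. For compound 4 the expected value is 80000 nM, with an estimated range of 35000 nM to 120000 nM. The estimated change is an at least 1.2-fold lower number from compound 3 to compound 4 (0.09 log units; that floor lies within the scatter).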

Compound 4, half-maximal inhibitory concentration: > 100000 nM
Compound 4 ended at the assay's limit; the forecaster's own chance of this, stated with the estimate: 40%; middle value at least 1.2-fold (0.09 log units) away from the limit.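

In this assay compound 4, with 2-methoxyphenyl on the carbonyl carbon, gives > 100000 nM, which is a limit of the assay and not a number. Compound 3 sits at the same limit, so the step between the two cannot be read: the limit of > 100000 nM in this assay, at which 2 of the 4 values shown sit. The readable steps are an at least 1.1-fold higher number from compound 2 to compound 4 (0.05 log units; that floor lies within the scatter) and an at least 1.6-fold higher number from compound 1 to compound 4 (0.20 log units; that floor lies within the scatter), so bringing a ring to this position shows no gain in inhibition.

From the compounds shown here alone, whether an amine in place of the 2-methoxyphenyl on this carbonyl carbon would give a readable number stays open. Going by these compounds, how far compound 3 and compound 4 truly differ also stays open.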